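The source may hold more compounds than are shown below. What is called first, only, known or untested is meant among the compounds shown, and "the series" means these compounds.

Of the compounds shown here, two of the same family have been measured in an assay on isolated protein for inhibition of somatostatin receptor type 2 (Homo sapiens), tested at 10 uM; on this read-out higher numbers stand for weaker inhibition and lower numbers for stronger inhibition. Compound 1 `NCCCCCn1c(SCCc2c[nH]c3ccccc23)nnc1-c1ccc2ccccc2c1` gives 610 nM. Compound 2 `NCCCCn1c(SCCc2c[nH]c3ccccc23)nnc1-c1cnc2ccccc2n1` gives 32 nM, the lower of the two numbers, and the gap to compound 1 lies well beyond the usual scatter of this assay. Compound 2 therefore stands as the stronger inhibitor of the pair.

Compound 3 `CCc1ccc(-c2nnc(SCCc3c[nH]c4ccccc34)n2CCCCN)cc1` has not yet been measured in this assay. It keeps the core and the 4-aminobutyl group of compound 2 and differs in one place: 4-ethylphenyl in place of quinoxalin-2-yl on an aromatic carbon. The group that leaves carries two hydrogen-bond acceptors, the group that enters carries none. Because compound 1 gives 610 nM with a large group that is also free of acceptors, though it differs from compound 2 in a second place as well, the number for compound 3 is expected to move upward, toward weaker inhibition, by a step of about a 9.4-fold higher number from compound 2 to compound 3 (0.97 log units; beyond the scatter). The estimate for compound 3 in this assay is 300 nM, with a range from 60 nM to 1500 nM.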

Compound 3, inhibition constant: 430 nM
Compound 3: middle estimate off by 1.4-fold (0.16 log units), on the low side; measured number inside the range.
By their numbers in this assay, from the lowest: compound 2; then compounds 3 and 1 (each within the scatter of the next).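

In this assay, for the compounds shown here, placing 4-ethylphenyl in place of quinoxalin-2-yl gives a 13-fold higher number from compound 2 to compound 3 (1.13 log units; beyond the scatter), the first step here in which only one place changes while the core and the 4-aminobutyl group stay the same. This shows that the group on this aromatic carbon can by itself shift the number well beyond the scatter, and that this change moves it toward weaker inhibition. The swap alters several features at once: the group that leaves has a second ring, ring nitrogen atoms and hydrogen-bond acceptors, the group that enters has none of these, and no measurement here explains the step or separates these features.

Still open, on these data alone, is which of these differences matters, and a group such as quinolin-2-yl, which keeps the second ring but has fewer ring nitrogen atoms, would help to separate them. As far as these compounds go, it is also open whether the ethyl group plays any part in the step, and pyridin-3-yl or 4-methoxyphenyl on the same carbon would test whether a one-ring group carrying a hetero atom behaves more like quinoxalin-2-yl or like 4-ethylphenyl.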